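A few compounds are considered here, and "the series" means these few. Any claim that something is new, unique, unknown or untested is made for them only; others in the source may bear on it.

Measured so far:
compound 1 `COc1ccc(-c2cc(C(=O)N(C)C)ccn2)cc1S(=O)(=O)Nc1cccc(NCCNC(=O)c2cccc(C)c2)c1` — 93%
compound 2 `COc1ccc(-c2csc(C(=O)N(C)C)c2)cc1S(=O)(=O)Nc1cccc(NCCNC(=O)c2cccc(C)c2)c1` — 59%
compound 3 `COc1ccc(-c2cccc(C(=O)N(C)CCN(C)C)c2)cc1S(=O)(=O)Nc1cccc(NCCNC(=O)c2cccc(C)c2)c1` — 102%

All three were tested in a functional assay on CHO-RD-HGA16 cells for agonist activity at Orexin/Hypocretin receptor type 1 (Homo sapiens), read by fluorescence and calcium flux, with a stated time of 30 min; a lower number here means a smaller maximal response, a higher number a larger maximal response. Compound 3 has the highest of the three numbers, but the number for compound 1 sits within the usual scatter of it, so the two cannot be told apart; compound 2 lies beyond the scatter below compound 3. Going by the values given here, the one measured step between compounds that differ in a single place is a number 34 percentage points lower from compound 1 to compound 2 (beyond the scatter). That step swaps the aromatic ring that carries the amide, not the group on the amide nitrogen.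

The next compound, compound 4 `COc1ccc(-c2cccc(C(=O)N(C)Cc3cccnc3)c2)cc1S(=O)(=O)Nc1cccc(NCCNC(=O)c2cccc(C)c2)c1`, differs from compound 3 in that one place: pyridin-3-yl in place of (dimethylamino)methyl on a saturated chain carbon bound to an amide-type nitrogen. Among the compounds with values here, no measured pair shows what happens when the group on this amide nitrogen is changed, so the step from compound 1 to compound 2 does not bear on it directly, and it gives no guidance on size or direction. With compound 3 already near the top of the measured range and nothing to suggest a loss, the expectation is a step that stays within the scatter. Compound 4 is thus expected to give about 95%, somewhere from 75% to 110%. That amounts to an expected a number 7 percentage points lower from compound 3 to compound 4 (within the scatter).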

Compound 4, largest response reached (Emax), in percent of the reference or control that the assay uses: 98%
Estimate against measurement, compound 4: 3 percentage points below, and the stated range covers the measured number.
By their numbers in this assay, from the lowest: compound 2; then compounds 1, 4 and 3 (each within the scatter of the next).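

In this assay there is a number 4 percentage points lower from compound 3 to compound 4 (within the scatter) when pyridin-3-yl takes the place of (dimethylamino)methyl on a saturated chain carbon bound to an amide-type nitrogen. Going by these compounds alone, this is the first measured pair that changes the group on this amide nitrogen, and it shows that an open end with no ring and 4 heavy atoms, and a six-membered aromatic ring with 1 hetero atom and 6 heavy atoms, give maximal responses that cannot be told apart. Nothing at hand explains why the maximal response holds across this change.

The compounds shown leave open whether the same holds for a phenyl ring, a pyridin-2-yl ring or a carboxylic acid at this place, or for a longer chain between the amide nitrogen and the ring. A maximal response also does not tell how much compound is needed to reach it, so compound 3 and compound 4 could still differ in that respect.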